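Removing one bromine from a twice-brominated core

A few compounds are considered here, and "the series" means these few. Any claim that something is new, unique, unknown or untested is made for them only; others in the source may bear on it.

The series is built on a shared core carrying two indole-type units on a central five-membered ring, and is tested in an assay on Rat-1 cells (Cricetulus griseus) for binding affinity to Alpha-1B adrenergic receptor (Homo sapiens); a lower number here means a stronger inhibitor, a higher number a weaker inhibitor. For the measured compounds named here, compound 1 `Brc1ccc2c(-c3c[nH]c(-c4c[nH]c5cc(Br)ccc45)n3)c[nH]c2c1` carries a bromine on each of its outer six-membered rings; in this assay compound 1 gives 520 nM, the higher of the two numbers measured so far. Compound 2 `Brc1ccc2c(-c3nc(-c4c[nH]c5ccccc45)c[nH]3)c[nH]c2c1` lacks one of those bromines and gives 130 nM, so a 4.0-fold lower number from compound 1 to compound 2 (0.60 log units; beyond the scatter).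

Compound 3 `Brc1ccc2c(-c3c[nH]c(-c4c[nH]c5ccccc45)n3)c[nH]c2c1` is the still unmeasured analogue in which the other bromine is removed: hydrogen in place of bromo on an aromatic carbon. Going by the values given here, the one measured step that bears on this change, the loss of a bromine from compound 1 to compound 2, lowered the number to a modest extent, and a similar move is expected here, so the step of a 3.5-fold lower number from compound 1 to compound 3 (0.54 log units; beyond the scatter) is the estimate. Compound 3 is therefore expected to give about 150 nM, within a range of 60 nM to 400 nM.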

Compound 3, inhibition constant: 170 nM
Beside the measured number, compound 3's estimate is 1.1-fold (0.05 log units) below it, within the range that was stated.
By their numbers in this assay, from the lowest: compounds 2 and 3 (each within the scatter of the next); then compound 1.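

Replacing this bromo group with hydrogen gives a 3.1-fold lower number from compound 1 to compound 3 (0.49 log units; beyond the scatter), so the lower number seen earlier on losing a bromine is not limited to one outer ring of compound 1. Either bromine can be removed with a similar result: compound 2 and compound 3 each keep one bromine, and their numbers lie within the scatter of each other. Nothing available explains why losing a bromine lowers the number.

The compounds shown leave open whether removing both bromines would lower the number further or leave it unchanged. They also leave open how a chlorine, a methoxy group or an amine on this same aromatic carbon would compare with bromo and hydrogen.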